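A few compounds are considered here, and "the series" means these few. Any claim that something is new, unique, unknown or untested is made for them only; others in the source may bear on it.

In a functional assay on A-375 cells (Homo sapiens) for antiproliferative activity, read by MTT assay, with a stated time of 24 h (a higher number here means a weaker inhibitor, a lower number a stronger inhibitor), compound 1 `Cc1ccc2nc(C(=O)Nc3c(F)cc(-c4cccc(F)c4)cc3F)c(C)c(O)c2c1` gives 90500 nM. Compound 2 `Cc1c(C(=O)Nc2c(F)cc(-c3cccc(F)c3)cc2F)nc2ccc(F)cc2c1O` gives 65300 nM, which is a 1.4-fold lower number from compound 1 to compound 2 (0.14 log units; within the scatter), so the two stand level. Compound 3 `CCOc1ccc2nc(C(=O)Nc3c(F)cc(-c4cccc(F)c4)cc3F)c(C)c(O)c2c1` is reported only as a limit, > 100000 nM.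

Compound 4 `Cc1c(C(=O)Nc2c(F)cc(-c3cccc(F)c3)cc2F)nc2ccc(OC(F)(F)F)cc2c1O` is built from compound 2 by one change, trifluoromethoxy in place of fluoro on an aromatic carbon. For the measured compounds named here, compound 4 itself has no measurement yet, so the closest guide is another group replacing fluoro on that carbon, which gave an at least 1.5-fold higher number from compound 2 to compound 3 (0.18 log units; that floor lies within the scatter). Replacing methyl with ethoxy gave an at least 1.1-fold higher number from compound 1 to compound 3 (0.04 log units; that floor lies within the scatter). Both figures are floors rather than true sizes, since compound 3 reached the limit. On this evidence, no step beyond the scatter is expected in this assay, though a slightly higher number is more likely than a lower one, and compound 4 may also end at the limit. The expected change is a 1.2-fold higher number from compound 2 to compound 4 (0.09 log units; within the scatter). For compound 4 the estimate is 80000 nM, with an expected range of 40000 nM to 160000 nM.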

Compound 4, half-maximal inhibitory concentration: 38300 nM
Beside the measured number, compound 4's estimate is 2.1-fold (0.32 log units) above it; measured number below the stated range.
By their numbers in this assay, from the lowest: compounds 4, 2 and 1 (each within the scatter of the next, the first and the last beyond it). At a limit, above all of these: compound 3.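

In this assay, for the compounds shown here, the earlier steps at this aromatic carbon all stayed within the scatter, but two steps to trifluoromethoxy go beyond it: a 2.4-fold lower number from compound 1 to compound 4 (0.37 log units; beyond the scatter), and an at least 2.6-fold lower number from compound 3 to compound 4 (0.41 log units; beyond the scatter). Against fluoro the change stays within the scatter, a 1.7-fold lower number from compound 2 to compound 4 (0.23 log units; within the scatter), so compound 2 and compound 4 stand level. Compound 3 and compound 4 both carry an oxygen on this carbon and differ in ethyl versus trifluoromethyl on that oxygen, so the oxygen alone does not settle the outcome, though the size of this step is only a floor: the limit of > 100000 nM in this assay, at which 1 of the 4 values shown sits.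

The compounds shown leave open whether any group on this carbon can bring the number far lower. An amine, a carboxylic acid or a longer ether chain there could show whether this position allows larger steps.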